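Pyridin-3-yl for Pyridin-4-yl: Expected Cytotoxicity

A few compounds are considered here, and "the series" means these few. Any claim that something is new, unique, unknown or untested is made for them only; others in the source may bear on it.

Compound 2 `Cc1nc(-c2cccnc2)sc1-c1nnc(-c2ccncc2)o1` was tested in an ADME assay on HeLa cells (Homo sapiens) for cytotoxicity, read by MTT assay; on this read-out higher numbers stand for lower toxicity in this test and lower numbers for higher toxicity in this test. In this assay compound 2 gives > 100 ug/mL, which is a limit of the assay rather than a number. Compound 1 `Cc1nc(-c2cccnc2)sc1-c1nnc(-c2ccccc2Cl)o1` gives > 100 ug/mL in this assay, again a limit. The step that the two limits leave unreadable from compound 1 to compound 2 is therefore unreadable, both values sitting at the limit of > 100 ug/mL in this assay, at which 2 of the 2 values shown sit. Compound 3 `Cc1nc(-c2cccnc2)sc1-c1nnc(-c2cccnc2)o1` differs from compound 2 by pyridin-3-yl in place of pyridin-4-yl on an aromatic carbon. Going by the values given here, no measured step gives a readable size for this change. The expected step that the limit leaves unreadable from compound 2 to compound 3 is none beyond the scatter, and compound 3 is estimated at 150 ug/mL with a range from 80 ug/mL to 400 ug/mL.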

Compound 3, half-maximal cytotoxic concentration: > 100 ug/mL
Compound 3 ended at the assay's limit; the forecaster's own chance of this, stated with the estimate: 75%; the middle value lies beyond the limit too.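

Going by these compounds alone, no step among compound 1, compound 2 and compound 3 can be read, because all three values are limits rather than numbers: the limit of > 100 ug/mL in this assay, at which 3 of the 3 values shown sit.

The compounds shown leave open whether any of these three groups changes the value in this assay at all, and what change to the shared core would bring a readable number.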